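The source may report more compounds than this note shows. Statements on the series, on what has been measured and on what is new or still open speak of the compounds shown alone.

Measured so far:
compound 1 `O=C(Nc1ccccc1)Nc1ncc([N+](=O)[O-])s1` - > 1000000 nM (a limit, not a number)
compound 2 `COc1ccc(NC(=O)Nc2ncc([N+](=O)[O-])s2)cc1` - "not determined" (no result reported)

The test in question is an ADME assay on Vero cells (Chlorocebus sabaeus) for cytotoxicity, read by sulforhodamine B assay, with a stated time of 48 h (on this read-out higher numbers stand for lower toxicity in this test and lower numbers for higher toxicity in this test), and it offers little to stand on. For compound 2 the entry is "not determined" (no result reported) and so compound 2 has no position of its own on the scale. Compound 1 sits at the limit of > 1000000 nM in this assay, at which 1 of the 2 values shown sits, and that reading is a limit of the assay.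

Not yet measured is compound 3 `CCCCOc1ccc(NC(=O)Nc2ncc([N+](=O)[O-])s2)cc1` in the same test. The structural change is propyl in place of hydrogen on a saturated chain carbon bound to an oxygen on an aromatic ring and it reads as methoxy to butoxy, with propyl in place of hydrogen on a saturated chain carbon bound to an oxygen on an aromatic ring.

Within the data shown here, no measured step exists to lean on. In this assay a step within the usual scatter is expected, or a modest move toward lower numbers. Compound 3 is expected at 500000 nM with an estimated range from 100000 nM to 1000000 nM as its bounds.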

Compound 3, half-maximal cytotoxic concentration: 58000 nM
For compound 3 the middle estimate is 8.6-fold (0.94 log units) above the measured one; measured number below the stated range.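

In this assay, butoxy in place of hydrogen on an aromatic carbon gives an at least 17-fold lower number from compound 1 to compound 3 (1.23 log units; beyond the scatter), so a change at this place can move the read-out toward higher toxicity in this test. This gives the series its first reading that is a number and not a limit. The size of the step is only a bound, because one end of it is a limit of the assay: the limit of > 1000000 nM in this assay, at which 1 of the 3 values shown sits.

The step from methoxy to butoxy cannot be read, so the compounds shown leave open whether the read-out in this assay follows the length of the chain at all or changes only once the chain reaches butoxy. They also leave open how a longer chain such as hexyloxy, or an amine or a carboxylic acid in this place, would read.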